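Compound 3 to compound 4: changing the carbonyl aryl group

This account rests on a few compounds, and the source may have more. Where it says the series, first, only, none or still open, it means among the compounds named here.

In a functional assay on MDA-MB-231 cells (Homo sapiens) for antiproliferative activity, with a stated time of 4 days (on this read-out lower numbers stand for stronger inhibition and higher numbers for weaker inhibition), compound 1 `CCCCc1ccc2[nH]c(-c3ccc(C(F)(F)F)cc3)c(C=O)c2c1` gives 33 nM as the lowest number of the series, compound 2 `CCCCc1ccc2[nH]c(-c3ccc(OC)cc3)c(/C=N/NC(=O)c3ccc(Cl)cc3)c2c1` gives 90 nM and compound 3 `CCCCc1ccc2[nH]c(-c3ccc(C(F)(F)F)cc3)c(/C=N/NC(=O)c3ccc(Cl)cc3)c2c1` gives 329 nM as the highest of the three. Compound 4 `CCCCc1ccc2[nH]c(-c3ccc(C(F)(F)F)cc3)c(/C=N/NC(=O)c3ccncc3)c2c1` keeps the rest of compound 3 and carries pyridin-4-yl in place of 4-chlorophenyl on a carbonyl carbon as its only difference.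

For the measured compounds named here, the one measured step, a 3.7-fold higher number from compound 2 to compound 3 (0.56 log units; beyond the scatter) for trifluoromethyl in place of methoxy on an aromatic carbon, is modest and concerns a different group. Going by the values given here, no measured pair varies the group on this carbonyl carbon, so the data offer no direction, and no step beyond the scatter is expected. The expected outcome is a 1.2-fold higher number from compound 3 to compound 4 (0.08 log units; within the scatter) as a working estimate only. The anchor is therefore compound 3 at 329 nM with a wide margin on both sides. Compound 4 is estimated at 400 nM in this assay with an expected range of 120 nM to 1300 nM for this untested change.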

Compound 4, half-maximal inhibitory concentration: 94 nM
Compound 4: the middle estimate sits 4.3-fold (0.63 log units) above what was measured, outside the stated range (below it).
By their numbers in this assay, from the lowest: compound 1; then compounds 2 and 4 (each within the scatter of the next); then compound 3.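

In this assay, for the compounds shown here, the group on this carbonyl carbon proves able to shift the read-out: pyridin-4-yl in place of 4-chlorophenyl gives a 3.5-fold lower number from compound 3 to compound 4 (0.54 log units; beyond the scatter) and is the first measured step at this position. The larger group of compound 4 still does not match the small group that compound 1 carries on the same aromatic carbon, with a 2.8-fold higher number from compound 1 to compound 4 (0.45 log units; beyond the scatter) remaining on that comparison. Nothing measured on these compounds accounts for the difference between the two aryl groups.

Plain phenyl or pyridin-3-yl on this carbonyl carbon would help separate the contribution of the ring nitrogen from that of losing the chlorine. On these data alone, whether pyridin-4-yl gives a similar step when methoxy replaces trifluoromethyl on the aromatic ring, as in compound 2, remains open.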